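Notes on a repeated ether change: compound 4 expected

This account rests on a few compounds, and the source may have more. Where it says the series, first, only, none or still open, it means among the compounds named here.

Compound 1 `COc1cc(CNC(=O)/C=C/c2ccccc2O)ccc1O` carries a free hydroxy on each of its two aromatic rings. In a functional assay on SH-SY5Y cells (Homo sapiens) for cytotoxicity, read by MTT assay, with stated times of 24 h and 4 h (on this read-out higher numbers stand for an effect only at larger amounts of compound and lower numbers for an effect already at smaller amounts), compound 1 gives 9760 nM. Compound 2 `COc1cc(CNC(=O)/C=C/c2ccccc2O)ccc1OCc1nc(C)c(C)nc1C` differs from compound 1 by (3,5,6-trimethylpyrazin-2-yl)methyl in place of hydrogen on an oxygen on an aromatic ring. In this assay compound 2 gives 5300 nM, so that a 1.8-fold lower number from compound 1 to compound 2 (0.27 log units; within the scatter). Compound 3 `COc1cc(CNC(=O)/C=C/c2ccc(O)cc2)ccc1OCc1nc(C)c(C)nc1C` differs from compound 2 by 4-hydroxyphenyl in place of 2-hydroxyphenyl on a double-bonded chain carbon bound to a double-bonded chain carbon. In this assay compound 3 gives 3740 nM, and a 1.4-fold lower number from compound 2 to compound 3 (0.15 log units; within the scatter). Compound 3 and compound 1 differ in more than one place; the difference between the two cores is not broken down here. Their two values show a gap that lies beyond the scatter, with compound 3 giving the lower number, whereas compound 3 and compound 2 sit within the scatter of each other.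

Compound 4 `COc1cc(CNC(=O)/C=C/c2ccc(OCc3nc(C)c(C)nc3C)cc2)ccc1OCc1nc(C)c(C)nc1C` is not yet measured in this assay. It differs from compound 3 by (3,5,6-trimethylpyrazin-2-yl)methyl in place of hydrogen on an oxygen on an aromatic ring. This is the same change as the one from compound 1 to compound 2, made at a place described in the same words, and it occurs twice among the compounds shown. That earlier step gave a 1.8-fold lower number from compound 1 to compound 2 (0.27 log units; within the scatter). The step from compound 3 to compound 4 is therefore expected to be about a 1.6-fold lower number from compound 3 to compound 4 (0.21 log units; within the scatter), resting on the step from compound 1 to compound 2 a 1.8-fold lower number from compound 1 to compound 2 (0.27 log units; within the scatter) and with no other repeat of the change to weigh against it. In this assay compound 4 is expected to give 2300 nM, estimated to fall between 900 nM and 6000 nM.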

Compound 4, half-maximal effective concentration: 7770 nM
Compound 4: the middle estimate sits 3.4-fold (0.53 log units) below what was measured, outside the stated range (above it).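

In this assay the (3,5,6-trimethylpyrazin-2-yl)methyl group in place of hydrogen on an oxygen on an aromatic ring gives a 2.1-fold higher number from compound 3 to compound 4 (0.32 log units; beyond the scatter), and the same change therefore does not carry over from one core to another as a fixed step: the same change on two cores in this assay, a 1.8-fold lower number (0.27 log units; within the scatter) from compound 1 to compound 2 and a 2.1-fold higher number (0.32 log units; beyond the scatter) from compound 3 to compound 4, 3.8-fold (0.58 log units) apart, beyond the scatter of two such steps. Within the data shown here, only the step on the core of compound 3 lies beyond the scatter, so the series shows a real shift toward a higher number on that core and no firm shift on the core of compound 1. The reason for the disagreement is not shown: there are only two pairs, the oxygen that takes the group lies on a different aromatic ring in each pair, and compound 3 already carries one copy of the group, so the effects of the core, the site and the second copy cannot be told apart.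

From the compounds shown here alone, it remains open whether the step on compound 3 is specific to (3,5,6-trimethylpyrazin-2-yl)methyl or would also appear with a plain benzyl group or a short chain ending in a carboxylic acid on the same oxygen. Going by these compounds, it also remains open whether the same change gives a step of similar size on further cores of this series.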